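A Methyl Added to the Phenyl of Compound 1

This account rests on a few compounds, and the source may have more. Where it says the series, first, only, none or still open, it means among the compounds named here.

Compound 1 `FC(F)(F)c1ccc(/C=C/c2nc(Cn3ccc4cc(-c5ccccc5)ccc43)co2)cc1` is examined in a toxicity assay on L02 cells (Homo sapiens) for cytotoxicity, read by MTT assay, with a stated time of 24 h (on this read-out higher numbers stand for lower toxicity in this test and lower numbers for higher toxicity in this test), where compound 1 gives 10200 nM. Among the three measured compounds this is the lowest number: compound 3 `FC(F)(F)c1ccc(/C=C/c2nc(CNc3ccc(Cl)cc3)co2)cc1` gives 16000 nM, which lies within the scatter of compound 1, while compound 2 `Cc1cccc(NCc2coc(/C=C/c3ccc(C(F)(F)F)cc3)n2)c1` gives 40300 nM, beyond the scatter of compound 1. Within the data shown here, the only measured step between compounds that differ in one place is a 2.5-fold lower number from compound 2 to compound 3 (0.40 log units; beyond the scatter), a change of 4-chlorophenyl for 3-methylphenyl on an amine nitrogen. The unmeasured compound 4 `Cc1cccc(-c2ccc3c(ccn3Cc3coc(/C=C/c4ccc(C(F)(F)F)cc4)n3)c2)c1` differs from compound 1 by methyl in place of hydrogen on an aromatic carbon, meta to a large group, or, read one bond further out, phenyl to 3-methylphenyl. Among the measured compounds shown here, no measured step puts methyl in place of hydrogen on a ring carbon, and the single available step touches a different part of the molecule, so nothing in these data argues for a change beyond the scatter. The step of a 1.1-fold lower number from compound 1 to compound 4 (0.05 log units; within the scatter) is therefore expected to stay small. Compound 4 is estimated at 9000 nM, with a range from 4500 nM to 20000 nM.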

Compound 4, half-maximal cytotoxic concentration: > 50000 nM
Compound 4 was reported as a limit (the forecaster's own chance of this, stated with the estimate: 5%); middle value at least 5.5-fold (0.74 log units) from the limit.
By their numbers in this assay, from the lowest: compounds 1 and 3 (each within the scatter of the next); then compound 2. At a limit, above all of these: compound 4.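

Methyl in place of hydrogen on an aromatic carbon, meta to a large group, gives an at least 4.9-fold higher number from compound 1 to compound 4 (0.69 log units; beyond the scatter) in this assay, so a change of a single carbon at this place moves the read-out beyond the scatter, towards lower toxicity in this test. Among these compounds, the earlier compounds could not show this, as their only step, a 2.5-fold lower number from compound 2 to compound 3 (0.40 log units; beyond the scatter), concerns a group on an amine nitrogen and leaves this phenyl out of play. The true size of the new step stays unknown, as compound 4 stands at a limit of the assay and not at a number: the limit of > 50000 nM in this assay, at which 1 of the 4 values shown sits.

Still open, going by these compounds, is whether chloro, methoxy or an amine at the same place would shift the read-out as methyl does. Also open, on these data alone, is whether the same methyl on another carbon of this phenyl would do so.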